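Working notes: methoxy on the saturated ring carbon

The source may hold more compounds than are shown below. What is called first, only, known or untested is meant among the compounds shown, and "the series" means these compounds.

Values in a functional assay for inhibition, with Homo sapiens as the target; on this read-out lower numbers stand for stronger inhibition and higher numbers for weaker inhibition:
- compound 1 `CC(C)=C1CS(=O)(=O)c2cc(C(=O)N=C(N)N)c(C)cc21`: 5030 nM
- compound 2 `Cc1cc2c(cc1C(=O)N=C(N)N)S(=O)(=O)C(C)(C)C2(C)O`: 102 nM
- compound 3 `Cc1cc2c(cc1C(=O)N=C(N)N)S(=O)(=O)C(C)(C)C2C`: 306 nM

Compound 3 (306 nM) sits between the other two numbers in this assay, with compound 2 lower (102 nM) and compound 1 higher (5030 nM).

Compound 4 `COC1c2cc(C)c(C(=O)N=C(N)N)cc2S(=O)(=O)C1(C)C` has not yet been measured. It differs from compound 3 by methoxy in place of methyl on a saturated ring carbon, two ring bonds from the ring sulfur (methoxy in place of methyl on a saturated ring carbon).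

Among the measured compounds shown here, one measured step bears on this carbon: a 3.0-fold higher number from compound 2 to compound 3 (0.48 log units; beyond the scatter), with hydrogen in place of hydroxy on a saturated ring carbon. For the measured compounds named here, that step is modest and is a different change, and no measured pair carries the methyl to methoxy swap itself, so it guides size and direction only loosely. In this assay the expectation is therefore a step no larger than that one, toward a lower number, and possibly none beyond the scatter. The expected step is a 1.7-fold lower number from compound 3 to compound 4 (0.23 log units; within the scatter) for this change. For compound 4 the estimated value is 180 nM, within an expected range of 60 nM to 550 nM.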

Compound 4, half-maximal inhibitory concentration: 138 nM
For compound 4 the middle estimate is 1.3-fold (0.12 log units) above the measured one; the measured number falls inside the stated range.
By their numbers in this assay, from the lowest: compounds 2 and 4 (each within the scatter of the next); then compound 3; then compound 1.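

In this assay, among the compounds shown here, the swap of methyl for methoxy on this saturated ring carbon gives a 2.2-fold lower number from compound 3 to compound 4 (0.35 log units; beyond the scatter), the first direct reading of this change, and it lies beyond the scatter. Alongside a 3.0-fold higher number from compound 2 to compound 3 (0.48 log units; beyond the scatter), this shows that compound 3 has a higher number than both hydroxy-bearing compound 2 and methoxy-bearing compound 4, while compound 2 and compound 4 lie within the scatter of each other, so the two groups cannot be ranked on these numbers even though their carbons also differ in whether a methyl group is present. Nothing available explains why the methoxy step has this direction or size.

As far as these compounds go, it remains open whether a longer ether such as ethoxy, or an amine on the same ring carbon, would stay in the range of compound 4 or move back toward compound 3. From the compounds shown here alone, it also remains open whether the step from methyl to methoxy depends on the neighbouring ring atom that bears two methyl groups, since every saturated-carbon comparison here keeps those two methyl groups in place.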